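This account rests on a few compounds, and the source may have more. Where it says the series, first, only, none or still open, it means among the compounds named here.

Measured compounds:
compound 1, `Cc1ccccc1OCC(=O)Nc1ccc(OCC(=O)O)c(F)c1`: 20.8%
compound 2, `Cc1cccc(OCC(=O)Nc2ccc(OCC(=O)O)c(F)c2)c1`: 45.4%
compound 3, `CC(C)(C)c1cccc(OCC(=O)Nc2ccc(OCC(=O)O)c(F)c2)c1`: 40.2%

The three compounds share one core and differ only in the substituted phenyl ring on the ether oxygen. In a functional assay on CHO cells for agonist activity at Free fatty acid receptor 1 (Homo sapiens), read by FLIPR, tested at 100 nM (a higher number here means a stronger effect of the compound at the concentration tested, a lower number a weaker effect), compound 1 gives 20.8%. Among the compounds with values here, the step of a number 24.6 percentage points higher from compound 1 to compound 2 (beyond the scatter) is the only change beyond the scatter among the measured pairs. The step of a number 5.2 percentage points lower from compound 2 to compound 3 (within the scatter) is within the scatter. Compound 3 therefore stands second highest of the three numbers: its nearest neighbour is compound 2, within the scatter, and compound 1 lies beyond the scatter below it.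

Compound 4, `COc1cccc(OCC(=O)Nc2ccc(OCC(=O)O)c(F)c2)c1`, differs from compound 3 by methoxy in place of tert-butyl on an aromatic carbon. Within the data shown here, the step that bears on this change is the one from compound 2 to compound 3, where the group on the same aromatic carbon was exchanged and this assay moved only within the scatter. Among the measured compounds shown here, no measured pair shows an oxygen-bearing group at that carbon, so the direction is open. Compound 4 is therefore expected to give a number close to that of compound 3, with a step of about a number 2.2 percentage points lower from compound 3 to compound 4 (within the scatter), within the scatter. The estimate for compound 4 is 38%, in the range 20% to 56%.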

Compound 4, a percentage reported as activity, at one concentration (the size of the read-out at that concentration, not a potency): 31.7%
For compound 4 the middle estimate is 6.3 percentage points above the measured one, and the stated range covers the measured number.
By their numbers in this assay, from the lowest: compound 1; then compounds 4, 3 and 2 (each within the scatter of the next, the first and the last beyond it).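

In this assay, methoxy and tert-butyl on this aromatic carbon are not separated, with a number 8.5 percentage points lower from compound 3 to compound 4 (within the scatter) as the step between them. Against methyl on the same carbon, the result is a number 13.7 percentage points lower from compound 2 to compound 4 (beyond the scatter) and so shows for the first time that the group at this carbon can shift the read-out beyond the scatter, since methyl and tert-butyl were not separated. Compared with the 2-methylphenyl group, the 3-methoxyphenyl group gives a number 10.9 percentage points higher from compound 1 to compound 4 (beyond the scatter) and so, like 3-methylphenyl, stays clear of compound 1 by more than the scatter.

As far as these compounds go, whether a chlorine, a hydroxyl or an amine on this carbon would read with methyl or with methoxy stays open. No measurement available here accounts for the difference between methyl and methoxy.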